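Cytotoxicity of aryl hydrazones on HEL cells

The compounds below may be only part of what the source reports. "The series", "measured", "known", "first", "only" and "open" are said of these compounds alone.

Measured so far:
compound 1, `O=C(COc1cccc2ccccc12)N/N=C/c1ccccc1Br`, 100 ug/mL
compound 2, `O=C(COc1cccc2ccccc12)N/N=C/c1c(O)ccc2ccccc12`, 1.94 ug/mL
compound 3, `O=C(COc1cccc2ccccc12)N/N=C/c1ccccc1[N+](=O)[O-]`, 100 ug/mL

In an ADME assay on HEL cells (Homo sapiens) for cytotoxicity (a higher number here means that more compound is tolerated, a lower number that less compound is tolerated), compound 1 stands level with compound 3 at the digits printed, and the two together give the highest numbers of the three; compound 2 lies far beneath them. Compound 4, `O=C(COc1cccc2ccccc12)N/N=C/c1ccc(F)cc1`, carries 4-fluorophenyl in place of 2-bromophenyl on a carbon with a double bond to nitrogen. Among the measured compounds shown here, the only step measured on this part of the molecule is no change at the digits printed from compound 1 to compound 3 (within the scatter), which left the number unchanged within the scatter. One halophenyl exchanged for another halophenyl is expected to behave alike, so the step of a 1.2-fold lower number from compound 1 to compound 4 (0.07 log units; within the scatter) is estimated to stay within the scatter. Compound 4 is therefore expected to give about 85 ug/mL in this assay, with a range from 30 ug/mL to 100 ug/mL.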

Compound 4, half-maximal cytotoxic concentration: 71.6 ug/mL
Beside the measured number, compound 4's estimate is 1.2-fold (0.07 log units) above it, and the stated range covers the measured number.
By their numbers in this assay, from the lowest: compound 2; then compounds 4, 1 and 3 (each within the scatter of the next).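

In this assay, the halogen can differ in both identity and place on the phenyl ring with little effect: 4-fluorophenyl for 2-bromophenyl gives a 1.4-fold lower number from compound 1 to compound 4 (0.15 log units; within the scatter). Among the compounds shown here, the earlier step changed only the group on a 2-substituted phenyl ring, so this is the first sign that a 4-substituted ring can also read like compound 1. Compounds 1, 3 and 4 therefore sit together, while compound 2 goes against this pattern at 1.94 ug/mL.

On these data alone, whether a phenyl ring carrying an amine or a carboxylic acid would read the same remains open. Why compound 2 stands apart also remains open, as no measurement shown gives a reason for any of these numbers.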